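From a Hydroxyphenyl Arm to a Chlorophenyl Arm

The source may report more compounds than this note shows. Statements on the series, on what has been measured and on what is new or still open speak of the compounds shown alone.

Of the compounds shown here, two that share a core have been tested in a functional assay on PCO3 cells (Homo sapiens) for cytotoxicity, read by sulforhodamine B assay; on this read-out higher numbers stand for weaker inhibition of growth and lower numbers for stronger inhibition of growth. Compound 1 `CC1=CC[C@@H]([C@@](C)(O)CCCC(C)(C)NC=S)CC1` gives 72000 nM in this assay. Compound 2 `CC1=CC[C@@H]([C@@](C)(O)CCCC(C)(C)NC(=S)N/N=C\c2ccc(O)cc2)CC1`, which carries a 4-hydroxyphenyl group on a carbon with a double bond to nitrogen, gives 13900 nM, the lower of the two numbers, and its gap to compound 1 lies beyond the usual scatter. Compound 3 `CC1=CC[C@@H]([C@@](C)(O)CCCC(C)(C)NC(=S)N/N=C\c2ccccc2Cl)CC1` differs from compound 2 in one place: 2-chlorophenyl in place of 4-hydroxyphenyl on a carbon with a double bond to nitrogen. Going by the values given here, no measured pair here shows what exchanging one aromatic ring for another does to growth inhibition, so the size of this step cannot be read off earlier results. The expected step of a 1.4-fold lower number from compound 2 to compound 3 (0.14 log units; within the scatter) is small, likely within the scatter, with a slight lean toward stronger inhibition. Compound 3 is therefore estimated at 10000 nM, within a range from 3000 nM to 35000 nM.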

Compound 3, concentration for total growth inhibition: > 100000 nM
Compound 3: only a limit was reported (the forecaster's own chance of this, stated with the estimate: 5%); at least 10-fold (1.00 log units) between middle value and limit.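

In this assay, 2-chlorophenyl in place of 4-hydroxyphenyl on a carbon with a double bond to nitrogen gives an at least 7.1-fold higher number from compound 2 to compound 3 (0.85 log units; beyond the scatter), so growth inhibition is clearly weaker. This shows that the aromatic arm at this place is not interchangeable: the two groups share the same ring and the same count of heavy atoms, yet the hydrogen-bond donor and acceptor of 4-hydroxyphenyl are absent from 2-chlorophenyl. Compound 3 gives only a limit rather than a number, so the full size of the step remains unknown: the limit of > 100000 nM in this assay, at which 1 of the 3 values shown sits.

The compounds shown do not separate the loss of the hydroxy group from the gain of chlorine, since both changes come in a single step. A plain phenyl ring or a methoxy group on the ring could help tell these two effects apart.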